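From methylpyrrole to pyrazole on the sulfonyl group

The compounds below may be only part of what the source reports. "The series", "measured", "known", "first", "only" and "open" are said of these compounds alone.

Compound 1 `NC[C@@H]1CCCc2cc(S(=O)(=O)c3cccc(O)c3)ccc21` gives 0.251 nM in an assay on isolated protein for displacement of a labelled ligand from 5-hydroxytryptamine receptor 6 (Homo sapiens); a lower number here means a stronger inhibitor, a higher number a weaker inhibitor.
Compound 2 `NC[C@@H]1CCCc2cc(S(=O)(=O)c3cc[nH]c3)ccc21` gives 0.316 nM in this assay.
Compound 3 `Cn1ccc(S(=O)(=O)c2ccc3c(c2)CCC[C@H]3CN)c1` gives 7.94 nM in this assay.

Compound 3 stands at the highest number of the three, the weakest binder here: the steps to it were a 25-fold higher number from compound 2 to compound 3 (1.40 log units; beyond the scatter) and a 32-fold higher number from compound 1 to compound 3 (1.50 log units; beyond the scatter). Compound 4 `NC[C@@H]1CCCc2cc(S(=O)(=O)c3cn[nH]c3)ccc21` differs from compound 3 by 1H-pyrazol-4-yl in place of 1-methyl-1H-pyrrol-3-yl on a sulfonyl sulfur. This change undoes the methyl on the aromatic nitrogen, the one alteration that cost so much from compound 2 to compound 3, while the second ring nitrogen of the pyrazole has no measured counterpart among these compounds. A large fall in the number is therefore expected, estimated as a 16-fold lower number from compound 3 to compound 4 (1.20 log units; beyond the scatter). Compound 4 is expected to give about 0.5 nM in this assay, within a range of 0.15 nM to 2.5 nM.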

Compound 4, inhibition constant: 2 nM
Estimate against measurement, compound 4: 4.0-fold (0.60 log units) below; measured number inside the range.
By their numbers in this assay, from the lowest: compounds 1 and 2 (each within the scatter of the next); then compound 4; then compound 3.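

Replacing 1-methyl-1H-pyrrol-3-yl with 1H-pyrazol-4-yl on the sulfonyl sulfur recovers only part of the lost binding, with a 4.0-fold lower number from compound 3 to compound 4 (0.60 log units; beyond the scatter) in this assay. Having no methyl on the ring nitrogen is therefore not enough for the lowest numbers: 1H-pyrazol-4-yl in place of 1H-pyrrol-3-yl gives a 6.3-fold higher number from compound 2 to compound 4 (0.80 log units; beyond the scatter) and in place of 3-hydroxyphenyl gives an 8.0-fold higher number from compound 1 to compound 4 (0.90 log units; beyond the scatter) at this position. No evidence here explains these steps.

As far as these compounds go, whether 1-methyl-1H-pyrazol-4-yl would bring a further rise stays open. So does the effect of an amine or a carboxylic acid on the pyrazole ring.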